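Fluoro for Chloro on the Phenyl Ring of Compound 3

This account rests on a few compounds, and the source may have more. Where it says the series, first, only, none or still open, it means among the compounds named here.

Compound 3 `S=C(N/N=C/c1ccc2ccccc2n1)Nc1ccc(Cl)cc1` sits at the second highest of the three numbers measured in a functional assay on HT-29 cells (Homo sapiens) for antiproliferative activity, read by sulforhodamine B assay, with a stated time of 72 h (on this read-out higher numbers stand for weaker inhibition and lower numbers for stronger inhibition), where compound 3 gives 97200 nM. Its nearest neighbour is compound 1 `NC(=S)N/N=C/c1ccc2ccccc2n1`, which in this assay gives 100000 nM; that pair differ by a 1.0-fold lower number from compound 1 to compound 3 (0.01 log units; within the scatter). Among the measured compounds shown here, compound 2 `Cc1ccccc1NC(=S)N/N=C/c1ccc2ccccc2n1` gives 42300 nM in this assay, and a 2.3-fold higher number from compound 2 to compound 3 (0.36 log units; beyond the scatter) is the only modest step touching compound 3. Compound 4 `Fc1ccc(NC(=S)N/N=C/c2ccc3ccccc3n2)cc1` differs from compound 3 by fluoro in place of chloro on an aromatic carbon. For the measured compounds named here, no measured step exchanges one halogen for another; the nearest comparison, a 1.0-fold lower number from compound 1 to compound 3 (0.01 log units; within the scatter), shows no difference beyond the scatter when 4-chlorophenyl replaces hydrogen. Compound 4 is therefore expected to show a 1.0-fold lower number from compound 3 to compound 4 (0.01 log units; within the scatter), a step within the scatter. The estimate for compound 4 in this assay is 95000 nM, between 45000 nM and 200000 nM.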

Compound 4, half-maximal inhibitory concentration: 28500 nM
The estimate for compound 4 lay 3.3-fold (0.52 log units) above the measured number; the whole stated range lies above it.
By their numbers in this assay, from the lowest: compounds 4 and 2 (each within the scatter of the next); then compounds 3 and 1 (each within the scatter of the next).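

In this assay, the halogen at this position matters: fluoro in place of chloro gives a 3.4-fold lower number from compound 3 to compound 4 (0.53 log units; beyond the scatter), whereas 4-chlorophenyl in place of hydrogen had shown no step beyond the scatter. The 4-fluorophenyl group does move the number away from that of the hydrogen compound, with a 3.5-fold lower number from compound 1 to compound 4 (0.55 log units; beyond the scatter), while a 1.5-fold lower number from compound 2 to compound 4 (0.17 log units; within the scatter) leaves it within the scatter of the 2-methylphenyl compound. From the compounds shown here alone, whether a bromo, a methoxy or an amine on this aromatic carbon would fall with fluoro or with chloro stays open. Nothing measured here accounts for the gap between the two halogens.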